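Nitro in Place of Methyl: Expected Effect on Cell Growth

This account rests on a few compounds, and the source may have more. Where it says the series, first, only, none or still open, it means among the compounds named here.

Going by the values given here, compound 1 `CCOC(=O)c1oc2ccc(NS(=O)(=O)c3cccc(C)c3)cc2c1C` gives 29500 nM in a functional assay on MDA-MB-231 cells (Homo sapiens) for antiproliferative activity, read by MTT assay, with a stated time of 72 h (on this read-out lower numbers stand for stronger inhibition and higher numbers for weaker inhibition), the lower end of the two numbers so far, with compound 2 within the scatter of it. Compound 2 `CCOC(=O)c1oc2ccc(NS(=O)(=O)c3ccc([N+](=O)[O-])cc3)cc2c1C` gives 33100 nM in this assay, and the step of a 1.1-fold higher number from compound 1 to compound 2 (0.05 log units; within the scatter) lies within the scatter. Compound 3 `CCOC(=O)c1oc2ccc(NS(=O)(=O)c3cccc([N+](=O)[O-])c3)cc2c1C` differs from compound 1 by nitro in place of methyl on an aromatic carbon. Among the compounds with values here, the only step that bears on this change is a 1.1-fold higher number from compound 1 to compound 2 (0.05 log units; within the scatter), so no step beyond the scatter is expected in this assay. Compound 3 is therefore expected to give 31000 nM, within 15000 nM to 65000 nM, an expected step of a 1.1-fold higher number from compound 1 to compound 3 (0.02 log units; within the scatter).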

Compound 3, half-maximal inhibitory concentration: 59900 nM
Compound 3: middle estimate off by 1.9-fold (0.29 log units), on the low side; the range from low to high includes it.
By their numbers in this assay, from the lowest: compounds 1, 2 and 3 (each within the scatter of the next, the first and the last beyond it).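

Going by these compounds alone, on this aromatic carbon, nitro in place of methyl gives the first step beyond the scatter in this assay (a 2.0-fold higher number from compound 1 to compound 3 (0.31 log units; beyond the scatter)), a modest loss of growth inhibition. Moving the nitro, with 3-nitrophenyl in place of 4-nitrophenyl, stays within the scatter (a 1.8-fold higher number from compound 2 to compound 3 (0.26 log units; within the scatter)), so these two placings cannot be told apart. No measured evidence accounts for the change.

From the compounds shown here alone, how an amine, a carboxylic acid or a longer chain at this position would compare with methyl remains open. So does whether any group here gives a clearly lower number than compound 1.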